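A few compounds are considered here, and "the series" means these few. Any claim that something is new, unique, unknown or untested is made for them only; others in the source may bear on it.

The set comprises three measured compounds and one that awaits measurement. Compound 1 `COCc1nc2nc(C)cc(Nc3ccc(C(F)(F)F)cc3)n2n1` gives 2.5 in a physicochemical assay for lipophilicity, at pH 7.4; a lower number here means a more polar compound, a higher number a more lipophilic compound. Compound 3 `Cc1cc(Nc2ccc(Cl)cc2)n2nc(C(C)C)nc2n1` gives 3.2. Compound 2 `CCC(F)(F)c1nc2nc(C)cc(Nc3ccc(S(F)(F)(F)(F)F)cc3)n2n1` gives 3.9, which is the highest of the three numbers: compound 3 sits nearest, lower by a margin beyond the scatter, and compound 1 lies furthest, lower by a larger margin that is also beyond the scatter.

Compound 4 `CSc1nc2nc(C)cc(Nc3ccc(S(F)(F)(F)(F)F)cc3)n2n1` has not yet been measured. Its structure differs from that of compound 2 in one place: methylsulfanyl in place of 1,1-difluoropropyl on an aromatic carbon. Among the measured compounds shown here, no pair of measured compounds differs in only one place, so the size of this kind of step cannot be read off from the measured data; the account instead rests on the general sense that a group with fewer heavy atoms replaces a larger one.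

Compound 4 is therefore expected to come out below compound 2, with a downward step of a number 0.60 log units lower from compound 2 to compound 4 (beyond the scatter) that goes beyond the scatter. For compound 4 the estimated value in this assay is 3.3, with a range from 2.8 to 3.8.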

Compound 4, distribution coefficient: 3.5
The estimate for compound 4 lay 0.20 log units below the measured number; the measured number falls inside the stated range.
By their numbers in this assay, from the lowest: compound 1; then compounds 3 and 4 (each within the scatter of the next); then compound 2.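

On an aromatic carbon of the five-membered aromatic ring with 3 nitrogen, between two ring nitrogen atoms, replacing 1,1-difluoropropyl with methylsulfanyl gives a modest step in this assay, a number 0.40 log units lower from compound 2 to compound 4 (beyond the scatter). Among the compounds shown here, this is the first comparison in the set that isolates a single place, as the earlier compounds differ from one another in more than one, and it shows that a change at this position alone, with the rest of the structure held constant, moves the number beyond the scatter. No measurement shown accounts for the size or direction of this step.

This single step on one background leaves open whether the same replacement would give a similar step on the core of compound 1 or compound 3, which differ from compound 2 and compound 4 elsewhere as well. Going by these compounds, how an amine, a methylsulfonyl group or a longer chain such as ethylsulfanyl at this position would compare with methylsulfanyl and 1,1-difluoropropyl in this assay also remains open.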